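Working notes: from compound 3 to compound 4

The source may hold more compounds than are shown below. What is called first, only, known or untested is meant among the compounds shown, and "the series" means these compounds.

Measured compounds:
compound 1 `CCCCCCNC(=S)N/N=C1\C(=O)Nc2ccc([N+](=O)[O-])cc21` — 25%
compound 2 `Cc1cccc(NC(=S)N/N=C2\C(=O)Nc3ccc([N+](=O)[O-])cc32)c1` — 10%
compound 3 `O=C1Nc2ccc([N+](=O)[O-])cc2/C1=N/NC(=S)Nc1ccc(I)cc1` — 5%

In a functional assay on the whole organism for inhibition, with Lemna aequinoctialis as the target, tested at 10 ug/mL (a lower number here means less inhibition of growth, a higher number more inhibition of growth at the concentration tested), compound 1 gives 25%, compound 2 gives 10% and compound 3 gives 5%. Compound 3 is separated from compound 1 by a number 20 percentage points lower from compound 1 to compound 3 (beyond the scatter), whereas the gap to compound 2, a number 5 percentage points lower from compound 2 to compound 3 (within the scatter), does not rise above the scatter, so compound 3 and compound 2 cannot be ordered against each other.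

Compound 4 `N#Cc1cccc(NC(=S)N/N=C2\C(=O)Nc3ccc([N+](=O)[O-])cc32)c1` is not yet measured. It differs from compound 3 by 3-cyanophenyl in place of 4-iodophenyl on an amide-type nitrogen. Among the measured compounds shown here, no measured step exchanges one substituted phenyl for another carrying a nitrile, so the bearing steps are indirect. The two steps that replace hexyl by an aryl group, a number 15 percentage points lower from compound 1 to compound 2 (beyond the scatter) and a number 20 percentage points lower from compound 1 to compound 3 (beyond the scatter), were both modest and of the same direction, and the step that changes one aryl for another, a number 5 percentage points lower from compound 2 to compound 3 (within the scatter), stayed within the scatter. The change to compound 4 keeps an aryl group on that nitrogen, so no step beyond the scatter is expected in this assay ; the estimated step is a number 3 percentage points higher from compound 3 to compound 4 (within the scatter).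

For compound 4 the expected result is 8%, with a range from 0% to 25%.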

Compound 4, percent growth inhibition at one concentration: 5%
Compound 4: middle estimate off by 3 percentage points, on the high side, and the stated range covers the measured number.
By their numbers in this assay, from the lowest: compounds 3, 4 and 2 (each within the scatter of the next); then compound 1.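

In this assay the exchange of 4-iodophenyl for 3-cyanophenyl on the amide-type nitrogen gives no change at the digits printed from compound 3 to compound 4 (within the scatter), and the exchange of methyl for cyano on an aromatic carbon gives a number 5 percentage points lower from compound 2 to compound 4 (within the scatter), so a nitrile, with its triple bond and hydrogen-bond acceptor, does not separate compound 4 from either aryl neighbour. The third replacement of hexyl by an aryl group gives a number 20 percentage points lower from compound 1 to compound 4 (beyond the scatter), which matches the direction of the two earlier replacements, so all three aryl compounds now read lower than compound 1 and none of those shown goes against this. No measurement at hand bears on the reason for these readings.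

The compounds shown leave open whether any group on the phenyl ring, such as an amine or a carboxylic acid, can move the reading beyond the scatter of the aryl compounds. They also leave open whether the higher reading of compound 1 belongs to the hexyl chain itself, which a shorter butyl chain or a longer octyl chain on the same nitrogen would test.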